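The source may hold more compounds than are shown below. What is called first, only, known or untested is meant among the compounds shown, and "the series" means these compounds.

Working notes on the series. Compound 3 `Oc1cccc(-c2cc(-c3ccccn3)nc(-c3ccccc3Cl)c2)c1` in a functional assay on T47D cells (Homo sapiens) for cytotoxicity, read by CCK-8 assay and cell counting, with a stated time of 2 days (on this read-out lower numbers stand for stronger inhibition and higher numbers for weaker inhibition), gives "not determined" (no result reported); the entry stands as not determined, so it gives no number against which a step can be placed. The nearest measured neighbours are compound 1 `Oc1ccc(-c2cc(-c3ccco3)nc(-c3ccccc3Cl)c2)cc1`, which carries the same furan-2-yl group as the new analogue and in this assay gives 5480 nM, and compound 2 `Oc1cccc(-c2cc(-c3cccs3)nc(-c3ccccc3Cl)c2)c1`, which carries the same 3-hydroxyphenyl group and in this assay gives 3990 nM. Those two values sit close to each other. Compound 4 `Oc1cccc(-c2cc(-c3ccco3)nc(-c3ccccc3Cl)c2)c1` is the next target. It differs from compound 3 by furan-2-yl in place of pyridin-2-yl on an aromatic carbon. With compound 3 unmeasured, no step size can be derived; the expectation rests on compound 1 and compound 2, whose values in this assay lie in the same band, so compound 4 is expected to land in that band too, with no step beyond the scatter foreseen in either direction. On that basis compound 4 is estimated at 4500 nM in this assay, with a range from 1500 nM to 14000 nM.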

Compound 4, half-maximal inhibitory concentration: 2010 nM
Beside the measured number, compound 4's estimate is 2.2-fold (0.35 log units) above it; the range from low to high includes it.
By their numbers in this assay, from the lowest: compounds 4, 2 and 1 (each within the scatter of the next, the first and the last beyond it).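

In this assay, furan-2-yl in place of thiophen-2-yl, with the 3-hydroxyphenyl group held constant, gives a 2.0-fold lower number from compound 2 to compound 4 (0.30 log units; within the scatter) and so does not separate these two five-membered rings at this position. Among the compounds shown here, with furan-2-yl held constant, 3-hydroxyphenyl in place of 4-hydroxyphenyl gives a 2.7-fold lower number from compound 1 to compound 4 (0.44 log units; beyond the scatter) as a modest change, the first single-place step to clear the scatter. No supporting measurement bears on the origin of either step.

The steps involving compound 3 cannot be read, so pyridin-2-yl remains unplaced against furan-2-yl and thiophen-2-yl. Also open, from the compounds shown here alone, is how an amine in place of furan-2-yl, or a carboxylic acid in place of the hydroxyl of compound 4, would read in this assay on the shared core.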